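The source may hold more compounds than are shown below. What is called first, only, known or untested is meant among the compounds shown, and "the series" means these compounds.

The study centres on compound 1, `CCCn1c(=O)[nH]c2nc(-c3ccc(S(=O)(=O)N4CCN(Cc5cccc(Br)c5)CC4)cc3)[nH]c2c1=O`, which in an assay on CHO cells for displacement of a labelled ligand from adenosine receptor A1 (Homo sapiens), read by scintillation counting, with a stated time of 90 min, in the presence of a further agent that is not named here (on this read-out lower numbers stand for stronger inhibition and higher numbers for weaker inhibition), gives 928 nM. Its companion compound 2, `CCCn1c(=O)[nH]c2nc(-c3ccc(S(=O)(=O)N4CCN(c5ccccc5)C(C)C4)cc3)[nH]c2c1=O`, is measured in this assay too, yet compound 2 gives only a limit of > 1000 nM and not a number. So compound 1 stands as the sole compound of the pair with a numerical result, the other sitting at the limit of > 1000 nM in this assay, at which 1 of the 2 values shown sits.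

The next compound to be examined is compound 3, `CCCn1c(=O)[nH]c2nc(-c3ccc(S(=O)(=O)N4CCN(c5ccccc5Cl)CC4)cc3)[nH]c2c1=O`. It differs from compound 1 in one place, (2-chlorophenyl in place of 3-bromobenzyl on an amine nitrogen in a ring). In compound 3, as in compound 2, an aromatic ring sits directly on the amine nitrogen in the ring, whereas in compound 1 a one-carbon link stands between them.

For the measured compounds named here, no measured pair in this set shows the effect of such a change. Going from the benzyl to the directly attached aryl, she expects a move toward weaker inhibition, a 2.2-fold higher number from compound 1 to compound 3 (0.33 log units; beyond the scatter), larger than the usual scatter, since compound 2 with its directly attached aryl reached only a limit of > 1000 nM. For compound 3 she therefore estimates 2000 nM, within a range from 700 nM to 6000 nM.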

Compound 3, inhibition constant: > 1000 nM
Compound 3 ended at the assay's limit; the forecaster's own chance of this, stated with the estimate: 55%; the middle value does not contradict the limit.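

In this assay compound 3 gives > 1000 nM, which is a limit of the assay and not a number. Placing 2-chlorophenyl in place of 3-bromobenzyl on the amine nitrogen in the ring gives an at least 1.0-fold higher number from compound 1 to compound 3 (0.03 log units; that floor lies within the scatter), so this position now has its first step, but that step is only a floor and does not show how large the change really is. The new result adds one more compound to those without a numerical value, leaving compound 1 as the only compound here with a number on which to judge changes at this position:  the limit of > 1000 nM in this assay, at which 2 of the 3 values shown sit.

The change replaces the one-carbon link and swaps the halogen and its place on the aromatic ring all at once, so the compounds shown cannot separate these contributions. Going by these compounds, a longer chain between the ring nitrogen and the aromatic ring, or an unsubstituted benzyl group at this position, remains open, as does any effect of the change that lies beyond the limit of the assay.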